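Trading the Dichlorophenyl of Compound 3 for Methoxyphenyl

This account rests on a few compounds, and the source may have more. Where it says the series, first, only, none or still open, it means among the compounds named here.

Of the compounds shown here, three sharing one core have been tested in a functional assay on Capan-2 cells (Homo sapiens) for inhibition, read by MTT assay, with a stated time of 72 h; a higher number here means a weaker inhibitor of growth, a lower number a stronger inhibitor of growth. Compound 3 `O=S(=O)(NCCCNCc1ccc(Cl)c(Cl)c1)c1cc(C(F)(F)F)cc(C(F)(F)F)c1` gives 1800 nM, the lowest number of the three; compound 1 `COc1cccc(CNCCCNS(=O)(=O)c2cc(C(F)(F)F)cc(C(F)(F)F)c2)c1` gives 6400 nM and compound 2 `O=S(=O)(NCCCNCc1ccccc1)c1cc(C(F)(F)F)cc(C(F)(F)F)c1` gives 14000 nM. Compound 4 `COc1ccc(CNCCCNS(=O)(=O)c2cc(C(F)(F)F)cc(C(F)(F)F)c2)cc1` has not yet been measured; it differs from compound 3 by 4-methoxyphenyl in place of 3,4-dichlorophenyl on a saturated chain carbon bound to an amine nitrogen. Among the compounds with values here, the steps that bear on this change are a 7.8-fold lower number from compound 2 to compound 3 (0.89 log units; beyond the scatter) and a 3.6-fold lower number from compound 1 to compound 3 (0.55 log units; beyond the scatter), both modest, and in both the 3,4-dichlorophenyl group gave the lower number. Compound 1, carrying the 3-methoxyphenyl group, is the nearest measured relative of compound 4. Compound 4 is therefore expected to give an estimated 6000 nM, within a range of 2500 nM to 15000 nM. That estimate means an expected step of a 3.3-fold higher number from compound 3 to compound 4 (0.52 log units; beyond the scatter).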

Compound 4, concentration for 50% growth inhibition: 2400 nM
Beside the measured number, compound 4's estimate is 2.5-fold (0.40 log units) above it; the whole stated range lies above it.
By their numbers in this assay, from the lowest: compounds 3 and 4 (each within the scatter of the next); then compound 1; then compound 2.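

The 3,4-dichlorophenyl group is not needed for a low number at this position, since 4-methoxyphenyl does as well within the scatter (a 1.3-fold higher number from compound 3 to compound 4 (0.12 log units; within the scatter)). The methoxy group on the plain phenyl ring now shows a larger step (a 5.8-fold lower number from compound 2 to compound 4 (0.77 log units; beyond the scatter)), and 4-methoxyphenyl and 3-methoxyphenyl are not interchangeable (a 2.7-fold lower number from compound 1 to compound 4 (0.43 log units; beyond the scatter)). No evidence here explains any of these steps. Still open, going by these compounds, is whether a 4-chlorophenyl group, a ring carrying an amine or a carboxylic acid, or a longer chain would keep the number this low.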